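This account rests on a few compounds, and the source may have more. Where it says the series, first, only, none or still open, it means among the compounds named here.

In a functional assay on MDA-MB-468 cells (Homo sapiens) for cytotoxicity, read by MTT assay, with a stated time of 48 h (a higher number here means a weaker inhibitor, a lower number a stronger inhibitor), three compounds built on one shared core have been measured, all of them with numbers at the weak end. Compound 1 `O=C(COc1ccc(Cl)cc1)Nc1nc(-c2ccc(Br)cc2)cs1` gives 52100 nM. Compound 2 `Cc1cc(OCC(=O)Nc2nc(-c3ccc(Br)cc3)cs2)ccc1Cl`, in this assay, gives 52100 nM. Compound 3 `O=C(COc1ccccc1)Nc1nc(-c2ccc(Cl)cc2)cs1` gives 55300 nM in this assay; its numbers and those of compounds 1 and 2 sit within the scatter of one another, so no order among the three can be drawn.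

The change from compound 1 to compound 2 is methyl in place of hydrogen on an aromatic carbon, and it made the step of no change at the digits printed from compound 1 to compound 2 (within the scatter). Compound 4 `Cc1ccccc1OCC(=O)Nc1nc(-c2ccc(Cl)cc2)cs1` has not yet been measured; it differs from compound 3 by methyl in place of hydrogen on an aromatic carbon. The two changes read alike in words, yet they are the same kind of change rather than the same: in compound 2 the methyl sits ortho to a chloro group and meta to a large group, whereas in compound 4 it sits ortho to a large group. The difference between the core of compound 1 and the core of compound 3 is not broken down here.

Within the data shown here, with only the step from compound 1 to compound 2 to go on, and that one flat, compound 4 is expected to land close to compound 3, the estimated step being a 1.0-fold lower number from compound 3 to compound 4 (0.00 log units; within the scatter). The estimate for compound 4 in this assay is therefore 55000 nM, with an expected range from 25000 nM to 120000 nM.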

Compound 4, half-maximal inhibitory concentration: 40100 nM
For compound 4 the middle estimate is 1.4-fold (0.14 log units) above the measured one; low and high end bracket the measured number.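

In this assay, methyl in place of hydrogen on an aromatic carbon, here ortho to a large group, gives a 1.4-fold lower number from compound 3 to compound 4 (0.14 log units; within the scatter), so this step, like the earlier one, stays inside the usual scatter. Set side by side, the two steps do not differ, and the change reads the same on both cores: the same change on two cores in this assay, no change at the digits printed (within the scatter) from compound 1 to compound 2 and a 1.4-fold lower number (0.14 log units; within the scatter) from compound 3 to compound 4, 1.4-fold (0.14 log units) apart, within the scatter of two such steps

Among these compounds, this shows only that the methyl change left the number within the scatter on each of the two cores; it does not show that the change has any real effect on either core, so no effect of measurable size has been seen to carry over, and with only two pairs, and the methyl in a different place in each, core and place cannot be told apart.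

The compounds shown leave open whether anything other than methyl on the phenoxy ring, such as an amine, a carboxylic acid or a longer chain, would move the number beyond the scatter in this assay. They also leave open what the chloro and bromo groups each contribute, since the cores of compound 1 and compound 3 differ in more than one place.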